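Exchanging the Thiocarbonyl Substituent on a Shared Amide Core

The compounds below may be only part of what the source reports. "The series", "measured", "known", "first", "only" and "open" are said of these compounds alone.

Three compounds have been measured in a functional assay on A-375 cells (Homo sapiens) for antiproliferative activity, read by CCK-8 assay, with a stated time of 72 h, tested at 8 uM; on this read-out higher numbers stand for a stronger effect at the one concentration tested and lower numbers for a weaker effect:

compound 1 `CN(Cc1ccncc1)C(=S)SCc1ccc(C(=O)Nc2ccccc2N)cc1`: 86.1%
compound 2 `CN(C(=S)SCc1ccc(C(=O)Nc2ccccc2N)cc1)c1cccnc1`: 87.7%
compound 3 `CN1CCN(C(=S)SCc2ccc(C(=O)Nc3ccccc3N)cc2)CC1`: 91.6%

All three share the same core and differ only in the group attached to the thiocarbonyl carbon. Compound 3 sits at the top of these numbers, yet neither gap reaches beyond the scatter: a number 3.9 percentage points higher from compound 2 to compound 3 (within the scatter) and a number 5.5 percentage points higher from compound 1 to compound 3 (within the scatter). Likewise a number 1.6 percentage points higher from compound 1 to compound 2 (within the scatter).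

Compound 4 `Nc1ccccc1NC(=O)c1ccc(CSC(=S)N2CCc3ccccc32)cc1` continues this series with another exchange at the same place: 2,3-dihydro-1H-indol-1-yl in place of 4-methylpiperazin-1-yl on a thiocarbonyl carbon. The two steps that bear on it, from compound 1 and from compound 2 to compound 3, each changed the group on the thiocarbonyl carbon and each stayed within the scatter, so this position has so far tolerated quite different groups without a clear shift in this assay. On that basis the step of a number 3.6 percentage points lower from compound 3 to compound 4 (within the scatter) is expected to be small, with no direction beyond the scatter. Compound 4 is therefore estimated at 88%, within a range from 76% to 96%.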

Compound 4, a percentage reported as inhibition, at one concentration (the size of the read-out at that concentration, not a potency): 85.4%
Compound 4: middle estimate off by 2.6 percentage points, on the high side, within the range that was stated.
By their numbers in this assay, from the lowest: compounds 4, 1, 2 and 3 (each within the scatter of the next).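

Compound 4 brings a six-membered aromatic ring of carbon only into the group on the thiocarbonyl carbon, and in this assay this gives a number 6.2 percentage points lower from compound 3 to compound 4 (within the scatter), a number 2.3 percentage points lower from compound 2 to compound 4 (within the scatter) and a number 0.7 percentage points lower from compound 1 to compound 4 (within the scatter). This position therefore accepts the 2,3-dihydro-1H-indol-1-yl group as well, and none of the four groups now shown can be told apart from the others by this read-out. Nothing available here offers an explanation for this tolerance.

A read-out at one concentration gives only the size of the effect at that concentration, so the four compounds may still show a stronger or weaker effect at other concentrations in ways these numbers cannot show. Going by these compounds, it also remains open whether a group carrying a carboxylic acid, or a simple diethylamino group, on the thiocarbonyl carbon would give a similar number.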